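The compounds below may be only part of what the source reports. "The series", "measured", "known", "first", "only" and "open" are said of these compounds alone.

Of the compounds shown here, three from this series have been tested in an assay on CHO cells for antagonist activity at transient receptor potential cation channel subfamily V member 1 (Homo sapiens), read by FLIPR and calcium flux; on this read-out higher numbers stand for weaker inhibition and lower numbers for stronger inhibition. Compound 1 `CCCCCc1nc(C(F)(F)F)ccc1CNC(=O)C(C)c1ccc(NS(C)(=O)=O)c(F)c1` gives 1 nM in this assay, and it stands as the highest of the three numbers. Compound 2 `CCC1CCC(c2nc(C(F)(F)F)ccc2CNC(=O)[C@@H](C)c2ccc(NS(C)(=O)=O)c(F)c2)CC1` gives 0.2 nM in this assay, a lower number than compound 1, a gap beyond the scatter. Compound 3 `C[C@H](C(=O)NCc1ccc(C(F)(F)F)nc1C1CCC(C)(C)CC1)c1ccc(NS(C)(=O)=O)c(F)c1` gives 0.3 nM in this assay, also a lower number than compound 1 and also beyond the scatter. Among the measured compounds shown here, the one step between close neighbours, a 1.5-fold higher number from compound 2 to compound 3 (0.18 log units; within the scatter), shows that swapping one substituted cyclohexyl ring for another changes little.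

Compound 4 `CC(C(=O)NCc1ccc(C(F)(F)F)nc1C1CCC(F)(F)CC1)c1ccc(NS(C)(=O)=O)c(F)c1` has not yet been measured. It differs from compound 1 in one place: 4,4-difluorocyclohexyl in place of pentyl on an aromatic carbon. The relevant comparisons are those of compound 1 with compound 2 and compound 3, where a substituted cyclohexyl ring instead of a pentyl chain at the same place went with a clearly lower number, while the small step of a 1.5-fold higher number from compound 2 to compound 3 (0.18 log units; within the scatter) suggests the exact substitution on that ring matters little. Compound 4 is therefore expected to show a lower number than compound 1, an estimated 2.5-fold lower number from compound 1 to compound 4 (0.40 log units; beyond the scatter) in this assay. The estimate for compound 4 is 0.4 nM, with a range from 0.15 nM to 1.2 nM.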

Compound 4, inhibition constant: 1.5 nM
Compound 4: middle estimate off by 3.8-fold (0.57 log units), on the low side; measured number above the stated range.
By their numbers in this assay, from the lowest: compounds 2 and 3 (each within the scatter of the next); then compounds 1 and 4 (each within the scatter of the next).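

In this assay, a ring at this place does not by itself go with a lower number: the step of a 1.5-fold higher number from compound 1 to compound 4 (0.18 log units; within the scatter) puts the 4,4-difluorocyclohexyl compound level with the open pentyl chain on this aromatic carbon next to the ring nitrogen. What is attached to the ring therefore can count here, which the earlier step of a 1.5-fold higher number from compound 2 to compound 3 (0.18 log units; within the scatter) could not show, since it compared only 4-ethylcyclohexyl with 4,4-dimethylcyclohexyl; the printed values make the contrast plain, with compound 3 at 0.3 nM and compound 4, carrying the two fluorines, at 1.5 nM in the same assay. No measurement shown here accounts for this result.

The compounds shown leave open how plain cyclohexyl, with nothing attached to the ring, would read at this place, and so whether the two fluorines or the alkyl groups are what separates these ring compounds. As far as these compounds go, it also remains open how a 4-methylcyclohexyl, a 4-fluorocyclohexyl or a 4-aminocyclohexyl ring, or a phenyl ring, would fall relative to the values seen so far.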